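A few compounds are considered here, and "the series" means these few. Any claim that something is new, unique, unknown or untested is made for them only; others in the source may bear on it.

Measured in a functional assay on HepG2 cells (Homo sapiens) for antiproliferative activity, read by sulforhodamine B assay, with a stated time of 72 h; on this read-out lower numbers stand for stronger inhibition and higher numbers for weaker inhibition:
Compound 1 `O=C(Cn1nc(-c2ccccc2)c2ccccc2c1=O)Nc1ccc(Cl)cc1`: 10300 nM
Compound 2 `O=C(Cn1nc(-c2ccccc2)c2ccccc2c1=O)Nc1cccc(C(F)(F)F)c1`: 3500 nM

Of these two compounds, compound 2 has the lower number, 3500 nM, in this assay. The next structure is compound 3 `O=C(Cn1nc(Cc2ccccc2)c2ccccc2c1=O)Nc1cccc(C(F)(F)F)c1`, with benzyl in place of phenyl on an aromatic carbon. Among the compounds with values here, the only measured step is a 2.9-fold lower number from compound 1 to compound 2 (0.47 log units; beyond the scatter). It changes the group on the amide-type nitrogen, so it gives a rough sense of scale but no direct evidence for this new change. A modest rise is therefore expected, with little confidence in its direction: a 1.4-fold higher number from compound 2 to compound 3 (0.15 log units; within the scatter). For compound 3 the estimated value is 5000 nM, with an expected range of 1600 nM to 15000 nM.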

Compound 3, half-maximal inhibitory concentration: 3520 nM
Compound 3: middle estimate off by 1.4-fold (0.15 log units), on the high side; the measured number falls inside the stated range.
By their numbers in this assay, from the lowest: compounds 2 and 3 (each within the scatter of the next); then compound 1.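

In this assay, benzyl in place of phenyl on this aromatic carbon gives a 1.0-fold higher number from compound 2 to compound 3 (0.00 log units; within the scatter), so the two numbers cannot be told apart. This position therefore tolerates the swap from phenyl to benzyl, at least with 3-(trifluoromethyl)phenyl on the amide-type nitrogen. Nothing available explains why the two groups read alike. Still open, going by these compounds, is how an amine, a carboxylic acid or a longer chain would read at this carbon. Also open, on these data alone, is whether benzyl would read the same alongside the 4-chlorophenyl of compound 1.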